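This account rests on a few compounds, and the source may have more. Where it says the series, first, only, none or still open, it means among the compounds named here.

Within the data shown here, compound 1 `CCCCCCCCCCCC(=O)OC[C@H](CSC[C@@H](N)C(=O)NC(C)(C)CO)OC(=O)CCCCCCCCCCC` gives 15500 nM in an assay on HEK293 cells for agonist activity at Toll-like receptor 2 (Homo sapiens) (on this read-out lower numbers stand for an effect already at smaller amounts and higher numbers for an effect only at larger amounts of compound), the highest of the two numbers measured so far, whereas compound 2 `CCCCCCCCCCCC(=O)OC[C@H](CSC[C@@H](N)C(=O)NCCO)OC(=O)CCCCCCCCCCC` gives 24 nM. Among the measured compounds shown here, the only measured step is a 650-fold lower number from compound 1 to compound 2 (2.81 log units; beyond the scatter), and it shows how strongly the substituent on the amide nitrogen can move this read-out. Compound 3 `CCCCCCCCCCCC(=O)OC[C@H](CSC[C@@H](N)C(=O)NCCCC(C)(C)CO)OC(=O)CCCCCCCCCCC` differs from compound 1 by 4-(hydroxymethyl)-4-methylpentyl in place of 1-(hydroxymethyl)-1-methylethyl on an amide-type nitrogen. That single large step bears on this change, so a step in the same direction, though probably smaller, is expected: a 39-fold lower number from compound 1 to compound 3 (1.59 log units; beyond the scatter). Compound 3 is therefore estimated at 400 nM, within a range from 40 nM to 4000 nM.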

Compound 3, half-maximal effective concentration: 30700 nM
For compound 3 the middle estimate is 77-fold (1.89 log units) below the measured one; measured number above the stated range.
By their numbers in this assay, from the lowest: compound 2; then compounds 1 and 3 (each within the scatter of the next).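

Putting 4-(hydroxymethyl)-4-methylpentyl in place of 1-(hydroxymethyl)-1-methylethyl on the amide-type nitrogen gives no real shift in this assay, with a 2.0-fold higher number from compound 1 to compound 3 (0.30 log units; within the scatter), so the longer group does not bring back a low number. Set against 2-hydroxyethyl, the same group gives a 1300-fold higher number from compound 2 to compound 3 (3.11 log units; beyond the scatter), and of the three groups shown only 2-hydroxyethyl gives a low number. No available measurement explains this result. As far as these compounds go, it remains open whether the two methyl branches or the chain length decides, and whether an unbranched 3-hydroxypropyl or a 2-aminoethyl group on this nitrogen would keep the low number.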